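Working notes: from compound 3 to compound 4

The compounds below may be only part of what the source reports. "The series", "measured", "known", "first", "only" and "open" are said of these compounds alone.

Compounds measured so far in an assay on isolated protein for inhibition of sphingomyelin phosphodiesterase (Homo sapiens), read by fluorescence, with a stated time of 30 min; a lower number here means a stronger inhibitor, a higher number a weaker inhibitor:
compound 1 `O=C(NO)c1cccc(OCc2ccc(-c3ccc(Cl)cc3)cc2)c1` gives 8960 nM
compound 2 `COc1ccc(C(=O)NO)cc1OCc1ccc(-c2ccc(Cl)cc2)cc1` gives 340 nM
compound 3 `O=C(NO)c1cccc(OCc2ccc(-c3noc(-c4ccc(Br)cc4)n3)cc2)c1` gives > 100000 nM
compound 4 `O=C(NO)c1cccc(OCc2ccc(-c3noc(-c4cccc(F)c4)n3)cc2)c1` has not been measured

Compound 3 sits at the assay limit, which is not a number, as noted under (the limit of > 100000 nM in this assay, at which 1 of the 3 values shown sits). Among the measured compounds shown here, the only measured step, a 26-fold lower number from compound 1 to compound 2 (1.42 log units; beyond the scatter), concerns a different part of the shared core and does not bear on the change now considered, (3-fluorophenyl in place of 4-bromophenyl on an aromatic carbon). For the measured compounds named here, no measured step therefore informs the expectation; the step that the limit leaves unreadable from compound 3 to compound 4 is estimated as none resolvable, since compound 3 gives only a limit. Compound 4 is expected near 150000 nM, within 30000 nM to 1000000 nM, most likely again reported only as a limit.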

Compound 4, half-maximal inhibitory concentration: > 100000 nM
Compound 4 ended at the assay's limit; the forecaster's own chance of this, stated with the estimate: 75%; the middle value is on the limit's open side.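

Compound 3 and compound 4 both end as limits and not as numbers in this assay, so no step between them can be read: the limit of > 100000 nM in this assay, at which 2 of the 4 values shown sit.

Going by these compounds, whether 3-fluorophenyl and 4-bromophenyl differ at all in this assay's read-out remains open.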